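A few compounds are considered here, and "the series" means these few. Any claim that something is new, unique, unknown or untested is made for them only; others in the source may bear on it.

Compound 3 `COc1cc(-c2nnc(SCc3ccccc3)n2N2C(=O)c3ccccc3C2=O)cc(OC)c1OC` is the point of departure. In a functional assay on A549 cells (Homo sapiens) for cytotoxicity, read by MTT assay, with a stated time of 48 h (on this read-out higher numbers stand for weaker inhibition and lower numbers for stronger inhibition), compound 3 gives > 200000 nM, which is a limit of the assay and not a number. Compound 1 `C=CCSc1nnc(-c2cc(OC)c(OC)c(OC)c2)n1N1C(=O)c2ccccc2C1=O` in this assay gives > 200000 nM, also a limit. Compound 2 `COc1cc(-c2nnc(SCc3ccccc3Cl)n2N2C(=O)c3ccccc3C2=O)cc(OC)c1OC` in this assay gives > 200000 nM, again a limit. Because all three sit at the limit of > 200000 nM in this assay, at which 3 of the 3 values shown sit, the steps a step that the two limits leave unreadable from compound 1 to compound 3 and a step that the two limits leave unreadable from compound 2 to compound 3 cannot be sized, and neither can a step that the two limits leave unreadable from compound 1 to compound 2.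

Compound 4 `COc1ccc(C(=O)CSc2nnc(-c3cc(OC)c(OC)c(OC)c3)n2N2C(=O)c3ccccc3C2=O)cc1` carries (4-methoxyphenyl)carbonyl in place of phenyl on a saturated chain carbon bound to a sulfur. Among the measured compounds shown here, no measured step reads, so no direction can be drawn from them; the step of a number no higher from compound 3 to compound 4 (the limit leaves the size open) is therefore expected to be small or none, with compound 4 most likely left at the limit. Compound 4 is estimated at 200000 nM, between 50000 nM and 500000 nM.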

Compound 4, half-maximal inhibitory concentration: 30000 nM
The estimate for compound 4 lay 6.7-fold (0.82 log units) above the measured number; the measured number lies below the stated range.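

In this assay, the saturated chain carbon bound to a sulfur now proves to be a place where a change can be read: (4-methoxyphenyl)carbonyl gives an at least 6.6-fold lower number from compound 3 to compound 4 (0.82 log units; beyond the scatter) in place of phenyl, an at least 6.6-fold lower number from compound 2 to compound 4 (0.82 log units; beyond the scatter) in place of 2-chlorophenyl and an at least 6.6-fold lower number from compound 1 to compound 4 (0.82 log units; beyond the scatter) in place of vinyl. Compound 4 alone among the compounds shown leaves the limit, so these sizes are only lower bounds: the limit of > 200000 nM in this assay, at which 3 of the 4 values shown sit.

The compounds shown leave open whether the carbonyl or the methoxy carries this step. A plain phenylcarbonyl, or an amine or carboxylic acid at this place, would bear on that.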